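Cyano for Chloro on a Scaffold Without Toxicity

This account rests on a few compounds, and the source may have more. Where it says the series, first, only, none or still open, it means among the compounds named here.

Compound 1 `Cn1c(-c2cccc(Cl)c2)cnc1NC(=O)c1ccc(F)cc1` was examined in a toxicity assay on THP-1 cells (Homo sapiens) for inhibition; on this read-out lower numbers stand for higher toxicity in this test and higher numbers for lower toxicity in this test. In this assay compound 1 gives > 50000 nM, which is a limit of the assay and not a number. Compound 2 `Cn1c(-c2ccccc2)cnc1NC(=O)c1ccccc1` gives > 100000 nM, likewise a limit. Compound 3 `CCCCn1c(-c2ccc(OC)cc2)cnc1NC(=O)c1ccc(F)cc1` gives > 100000 nM, again only a limit. Compound 1 thus stands at the limit of > 50000 nM in this assay, at which 1 of the 3 values shown sits, while the other two stand at the limit of > 100000 nM in this assay, at which 2 of the 3 values shown sit; none of the three shows measurable toxicity here. Compound 4 `Cn1c(-c2cccc(C#N)c2)cnc1NC(=O)c1ccc(F)cc1` differs from compound 1 by cyano in place of chloro on an aromatic carbon. Going by the values given here, with no measured step between these compounds, no change beyond the scatter is expected in this assay a step that the limit leaves unreadable from compound 1 to compound 4, and compound 4 is expected most likely to return another limit. Compound 4 is therefore estimated at 100000 nM, between 50000 nM and 300000 nM.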

Compound 4, half-maximal cytotoxic concentration: > 100000 nM
Compound 4: a limit, no number (the forecaster's own chance of this, stated with the estimate: 85%); the middle value sits exactly at the limit.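

Compound 1 and compound 4 both return limits of the assay and not numbers, and no step can be read between them. The compounds shown leave open at what concentration, if any, toxicity would appear in this assay.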